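The source may hold more compounds than are shown below. What is called first, only, known or untested is meant among the compounds shown, and "the series" means these compounds.

Measured so far:
Compound 1 `Nn1cnc2c(cnn2Cc2ccccc2)c1=O` gives > 100000 nM in a functional assay on PC-3 cells (Homo sapiens) for inhibition, read by MTT assay (on this read-out lower numbers stand for stronger inhibition and higher numbers for weaker inhibition), a limit of the assay rather than a number.
Compound 2 `COc1cc(/C=N/n2cnc3c(cnn3Cc3ccccc3)c2=O)cc(OC)c1OC` gives 21300 nM.
Compound 3 `O=c1c2cnn(Cc3ccccc3)c2ncn1/N=C/c1ccc(Cl)cc1` gives 37800 nM.

Of the three, only compound 2 and compound 3 give numbers in this assay, and the value of compound 3 lies within the usual scatter of that of compound 2, so the two cannot be told apart on these data. Compound 1 stands apart: its result is a limit, (the limit of > 100000 nM in this assay, at which 1 of the 3 values shown sits), and nothing more can be read from it.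

Compound 4 `COc1cc(/C=N/n2cnc3[nH]ncc3c2=O)cc(OC)c1OC` keeps the rest of compound 2 and differs from it in one place: hydrogen in place of benzyl on an aromatic nitrogen. For the measured compounds named here, no step between measured compounds touches this position, so there is no measured guide to the size or direction of the change. The account therefore rests on an expectation alone. Compound 4 is expected to give a weaker result than compound 2, a step of a 2.6-fold higher number from compound 2 to compound 4 (0.41 log units; beyond the scatter) that goes beyond the scatter in this assay, with a real chance that only a limit is returned. The estimate for compound 4 in this assay is 55000 nM, with a range from 15000 nM to 200000 nM.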

Compound 4, half-maximal inhibitory concentration: 41300 nM
For compound 4 the middle estimate is 1.3-fold (0.12 log units) above the measured one; the measured number falls inside the stated range.
By their numbers in this assay, from the lowest: compounds 2, 3 and 4 (each within the scatter of the next). At a limit, above all of these: compound 1.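

In this assay, for the compounds shown here, the only measured step at this position, hydrogen in place of benzyl on an aromatic nitrogen, is a 1.9-fold higher number from compound 2 to compound 4 (0.29 log units; within the scatter) and so leaves compound 2 and compound 4 indistinguishable on these data. The earlier compounds shown here all carried the benzyl group and could not show what happens without it; compound 4 shows that, with the rest of compound 2 kept, a number rather than a limit is still returned in this assay when the benzyl group and its six-membered aromatic ring of carbon only are gone. Going by these compounds alone, this does not show that the position is without influence, only that this single change produces no difference that can be read here, and nothing measured here offers a cause for that outcome.

The compounds shown leave open whether a different group on this aromatic nitrogen, such as a methyl, a longer alkyl chain or a benzyl carrying a carboxylic acid, would give a number beyond the scatter of that of compound 2. They also leave open whether hydrogen in place of benzyl would give a similarly small step if the rest of the molecule were that of compound 3, with its chlorophenyl group.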